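Sulfonyl aryl exchange carried over to a second core

The source may report more compounds than this note shows. Statements on the series, on what has been measured and on what is new or still open speak of the compounds shown alone.

Of the compounds shown here, three have been measured in an assay on isolated protein for displacement of a labelled ligand from metabotropic glutamate receptor 5 (Homo sapiens), with a stated time of 60 min, tested at 1 uM; on this read-out higher numbers stand for more inhibition at the one concentration tested (going by the name of the read-out) and lower numbers for less inhibition. Compound 1 `CC1CCN(c2c(S(=O)(=O)c3cccc(Cl)c3)cnc3cc(Cl)ccc23)CC1` gives 92%, compound 2 `Cc1ccc(S(=O)(=O)c2cnc3cc(Cl)ccc3c2N2CCC(C)CC2)cc1` gives 94%, and compound 3 `Cc1ccc(S(=O)(=O)c2cnc3ccc(C)cc3c2N2CCC(C)CC2)cc1` gives 82%. Compound 2 and compound 1 differ by 3-chlorophenyl in place of 4-methylphenyl on a sulfonyl sulfur; this change made a number 2 percentage points lower from compound 2 to compound 1 (within the scatter). Compound 3 stands beyond the scatter below compound 2, while its gap to compound 1 is within the scatter. The difference between the core of compound 3 and the core of compound 2 is not broken down here.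

Compound 4 `Cc1ccc2ncc(S(=O)(=O)c3cccc(Cl)c3)c(N3CCC(C)CC3)c2c1` has not yet been measured in this assay. It differs from compound 3 by 3-chlorophenyl in place of 4-methylphenyl on a sulfonyl sulfur, the same kind of change as between compound 2 and compound 1, made on the core of compound 3. Because that earlier change gave a number 2 percentage points lower from compound 2 to compound 1 (within the scatter), compound 4 is expected to lie close to compound 3, with an estimated step of a number 2 percentage points lower from compound 3 to compound 4 (within the scatter). In this assay compound 4 is therefore estimated at 80%, most likely between 68% and 90%.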

Compound 4, a percentage reported as inhibition, at one concentration (the size of the read-out at that concentration, not a potency): 91%
Beside the measured number, compound 4's estimate is 11 percentage points below it, and the stated range ends below it.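

In this assay, putting 3-chlorophenyl in place of 4-methylphenyl on the sulfonyl sulfur of the core of compound 3 gave a number 9 percentage points higher from compound 3 to compound 4 (within the scatter). Set beside the same exchange on the core of compound 2, the two steps cannot be told apart: the same change on two cores in this assay, a number 2 percentage points lower (within the scatter) from compound 2 to compound 1 and a number 9 percentage points higher (within the scatter) from compound 3 to compound 4, 11 percentage points apart, within the scatter of two such steps. This shows that in these two pairs the exchange stayed within the scatter on both cores, and that nothing here marks its outcome as dependent on the core; it does not show that the exchange would behave alike on any further core, and a percentage at one concentration is not a potency.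

The compounds shown leave open how the read-out would respond to a sulfonyl aryl group carrying an amine or a carboxylic acid rather than methyl or chlorine. They also leave open what a longer chain in place of the methyl on the core of compound 3 would do, and how far the gap between the two cores would hold for other sulfonyl groups.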